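Swapping the halogenated phenyl ring on the shared core

The source may report more compounds than this note shows. Statements on the series, on what has been measured and on what is new or still open speak of the compounds shown alone.

Measured so far:
Compound 1 `Fc1ccc(-c2cn3ccnc3c(-c3ccc4ncn(C5CCCCC5)c4c3)n2)cc1`: 9.17%
Compound 2 `Clc1ccc(-c2cn3ccnc3c(-c3ccc4ncn(C5CCCCC5)c4c3)n2)cc1`: 21.8%

In a functional assay on MCF7 cells (Homo sapiens) for inhibition, read by sulforhodamine B assay, with a stated time of 48 h, tested at 10 uM (a lower number here means less inhibition, a higher number more inhibition at the concentration tested (going by the name of the read-out)), compound 2 stands highest of the two measured compounds, and compound 1 lies a number 12.6 percentage points higher from compound 1 to compound 2 (beyond the scatter) behind it. Compound 3 `Fc1ccccc1-c1cn2ccnc2c(-c2ccc3ncn(C4CCCCC4)c3c2)n1` differs from compound 2 in one place: 2-fluorophenyl in place of 4-chlorophenyl on an aromatic carbon. For the measured compounds named here, the only measured step that bears on this, the one from compound 1 to compound 2, was a number 12.6 percentage points higher from compound 1 to compound 2 (beyond the scatter) and went from fluoro to chloro; here the fluoro returns, but at another position, which no measured pair covers. A downward step, a number 9.8 percentage points lower from compound 2 to compound 3 (within the scatter), is therefore expected. Compound 3 is estimated at 12%, in a range from 2% to 25%.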

Compound 3, a percentage reported as inhibition, at one concentration (the size of the read-out at that concentration, not a potency): 11.2%
Estimate against measurement, compound 3: 0.8 percentage points above; the range from low to high includes it.
By their numbers in this assay, from the lowest: compounds 1 and 3 (each within the scatter of the next); then compound 2.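

In this assay, replacing 4-chlorophenyl with 2-fluorophenyl gives a number 10.6 percentage points lower from compound 2 to compound 3 (beyond the scatter), while shifting the fluoro on the phenyl ring gives a number 2 percentage points higher from compound 1 to compound 3 (within the scatter). The position of the fluoro therefore makes no readable difference here, and among these three compounds only the 4-chlorophenyl of compound 2 stands apart. Nothing available explains that difference.

As far as these compounds go, it remains open whether 2-chlorophenyl would keep the level of compound 2, which would show whether the chloro holds up at the other position. From the compounds shown here alone, what an amine or a carboxylic acid on this phenyl ring would do in this assay also stays open.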